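Moving the Oxygen on the Phenyl Ring

This account rests on a few compounds, and the source may have more. Where it says the series, first, only, none or still open, it means among the compounds named here.

Compound 1 `CC(=O)N1N=C(c2ccc3ccccc3c2)OC1c1ccccc1` gives 2.11 ug/mL in a functional assay on HepG2 cells (Homo sapiens) for antiproliferative activity, read by MTT assay, with a stated time of 48 h; a higher number here means a weaker inhibitor, a lower number a stronger inhibitor.
Compound 2 `COc1ccc(C2OC(c3ccc4ccccc4c3)=NN2C(C)=O)cc1` gives 3.6 ug/mL in this assay.

Compound 2 stands at the upper end of the two numbers shown; its only neighbour is compound 1, separated by a 1.7-fold higher number from compound 1 to compound 2 (0.23 log units; within the scatter), a gap that falls within the scatter, so the two compounds cannot be told apart on these data.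

Compound 3 `CC(=O)N1N=C(c2ccc3ccccc3c2)OC1c1ccccc1O` is the unmeasured compound. The change from compound 2 is 2-hydroxyphenyl in place of 4-methoxyphenyl on a saturated ring carbon. Among the compounds with values here, the only measured step that touches this part of the shared core is the one from compound 1 to compound 2, where a methoxy replaced a hydrogen on an aromatic carbon, and that step was a 1.7-fold higher number from compound 1 to compound 2 (0.23 log units; within the scatter), within the scatter. Within the data shown here, no measured step shows a hydroxyl group, nor a change in where the oxygen sits on the phenyl ring, so the present change is only loosely covered.

Given that, compound 3 is expected to show no step beyond the scatter, with a 1.3-fold lower number from compound 2 to compound 3 (0.11 log units; within the scatter) as the estimated change. The estimate for compound 3 in this assay is 2.8 ug/mL, with a range from 1.2 ug/mL to 7 ug/mL.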

Compound 3, half-maximal inhibitory concentration: 1.84 ug/mL
Compound 3: the middle estimate sits 1.5-fold (0.18 log units) above what was measured, within the range that was stated.
By their numbers in this assay, from the lowest: compounds 3, 1 and 2 (each within the scatter of the next).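

In this assay, 2-hydroxyphenyl in place of 4-methoxyphenyl on the saturated ring carbon gives a 2.0-fold lower number from compound 2 to compound 3 (0.29 log units; within the scatter) and a hydroxy added to the unsubstituted phenyl group gives a 1.1-fold lower number from compound 1 to compound 3 (0.06 log units; within the scatter) so neither step can be told apart from the differences seen between repeated measurements. Until now this phenyl group had carried only a methoxy, whereas compound 3 shows that a hydroxy, which adds a hydrogen-bond donor, also leaves the result within the scatter of both earlier compounds, and that an oxygen group at a different place on the ring does the same. Nothing available here offers an explanation for these results.

Going by these compounds, what remains open is whether the kind of oxygen group or its place on the ring matters at all, a question that 4-hydroxyphenyl and 2-methoxyphenyl could help to separate. It is also unknown whether this position would respond beyond the scatter to a quite different group on the phenyl ring, such as an amine or a carboxylic acid.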